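A few compounds are considered here, and "the series" means these few. Any claim that something is new, unique, unknown or untested is made for them only; others in the source may bear on it.

Measured so far:
compound 1 `CCCCNc1nnc(SCC(=O)N(Cc2cccc([N+](=O)[O-])c2)c2ccc(F)cc2)s1`, 82.3%
compound 2 `C=CCNc1nnc(SCC(=O)N(Cc2cccc([N+](=O)[O-])c2)c2ccc(F)cc2)s1`, 86.4%
compound 3 `CC(C)Nc1nnc(SCC(=O)N(Cc2cccc([N+](=O)[O-])c2)c2ccc(F)cc2)s1`, 89.1%

All three numbers come from an assay on isolated protein for inhibition of Amine oxidase [flavin-containing] A (Homo sapiens), read by fluorescence and Amplex Red, with a stated time of 30 min, tested at 100 uM; on this read-out higher numbers stand for a stronger effect at the one concentration tested and lower numbers for a weaker effect. Compound 3 stands among three values that lie within the scatter of one another: a number 6.8 percentage points higher from compound 1 to compound 3 (within the scatter) and a number 2.7 percentage points higher from compound 2 to compound 3 (within the scatter), just as a number 4.1 percentage points higher from compound 1 to compound 2 (within the scatter). The next compound is compound 4 `CCNc1nnc(SCC(=O)N(Cc2cccc([N+](=O)[O-])c2)c2ccc(F)cc2)s1`, which differs from compound 3 by hydrogen in place of methyl on a saturated chain carbon bound to a nitrogen on an aromatic ring and a saturated chain carbon. Each measured step exchanges one alkyl group on the same nitrogen of the shared core, and none moved the read-out beyond the scatter, so the step to compound 4 is expected to be of the same kind, with no direction beyond the scatter. Compound 4 is therefore expected to give 86%, between 74% and 95%, meaning an expected step of a number 3.1 percentage points lower from compound 3 to compound 4 (within the scatter).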

Compound 4, a percentage reported as inhibition, at one concentration (the size of the read-out at that concentration, not a potency): 89.5%
For compound 4 the middle estimate is 3.5 percentage points below the measured one; the range from low to high includes it.
By their numbers in this assay, from the lowest: compounds 1, 2, 3 and 4 (each within the scatter of the next).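

Going from isopropyl to ethyl gives a number 0.4 percentage points higher from compound 3 to compound 4 (within the scatter) in this assay and so removes the branch without a shift beyond the scatter. Ethyl also gives a number 3.1 percentage points higher from compound 2 to compound 4 (within the scatter) against allyl and a number 7.2 percentage points higher from compound 1 to compound 4 (within the scatter) against butyl, so this read-out at the one concentration tested does not separate the four alkyl groups. Nothing available explains this flat result and no cause is assigned here.

Open, as far as these compounds go, is whether this tolerance extends beyond small alkyl groups, for example to a benzyl group, a cyclohexyl ring or a carboxylic acid on a chain. Also open, from the compounds shown here alone, is what a free amine, with hydrogen in place of ethyl, would give.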